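The source may report more compounds than this note shows. Statements on the series, on what has been measured and on what is new or still open speak of the compounds shown alone.

Measured compounds:
Compound 1 `C=C1CCC(c2csc(/C=C(\C)C(N)=O)c2)CC1` — in a functional assay on BGC-823 cells (Homo sapiens) for cytotoxicity, read by CCK-8 assay, with a stated time of 24 h (on this read-out higher numbers stand for weaker inhibition and lower numbers for stronger inhibition), compound 1 gives > 50000 nM, a limit of the assay rather than a number.
Compound 2 `C/C(=C\c1cc(-c2cccnc2)co1)C(N)=O` — in this assay compound 2 gives > 50000 nM, again a limit.
Compound 3 `C/C(=C\c1cc(-c2ccccc2)cs1)C(N)=O` — in this assay compound 3 gives > 50000 nM, also a limit.

Compound 3 therefore stands nowhere in particular among the numbers shown: all three measured compounds sit at the limit of > 50000 nM in this assay, at which 3 of the 3 values shown sit, and no step between them can be sized, so their values say only that none reached a measurable half-maximal inhibitory concentration.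

Compound 4 `C/C(=C\c1cc(-c2ccc(F)cc2)cs1)C(N)=O` differs from compound 3 by fluoro in place of hydrogen on an aromatic carbon. Among the compounds with values here, no measured step informs this change. With every measured compound at the limit, the expected outcome for compound 4 is that it stays at or near that limit, with no step beyond the scatter in this assay. The step from compound 3 to compound 4 is estimated as a step that the limit leaves unreadable from compound 3 to compound 4. For compound 4 the estimate in this assay is 60000 nM, between 15000 nM and 200000 nM, most likely reported as a limit again.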

Compound 4, half-maximal inhibitory concentration: > 50000 nM
Compound 4: only a limit was reported; the forecaster's own chance of this, stated with the estimate: 80%; the middle value is on the limit's open side.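

Compound 3 and compound 4 are both reported only as limits, so the step from hydrogen to fluoro between them cannot be read: the limit of > 50000 nM in this assay, at which 4 of the 4 values shown sit.

The compounds shown leave open whether any change to the shared core would give a measurable half-maximal inhibitory concentration.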